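The compounds below may be only part of what the source reports. "The series", "measured", "known", "first", "only" and "open" are said of these compounds alone.

Compound 1 `N#Cc1c(Cl)nc(SCc2nc3ccccc3[nH]2)nc1-c1ccccc1`: 4.46 nM
Compound 2 `N#Cc1c(Nc2ccccn2)nc(SCc2nc3ccccc3[nH]2)nc1-c1ccccc1`: 20 nM

In a functional assay on HL-60 cells (Homo sapiens) for cytotoxicity, read by MTT assay, with a stated time of 3 days (a lower number here means a stronger inhibitor, a higher number a weaker inhibitor), compound 2 gives 20 nM, the higher of the two numbers, which makes it the weaker inhibitor of the pair. Within the data shown here, its only neighbour is compound 1 at 4.46 nM.

The next compound, compound 3 `N#Cc1c(Nc2nccs2)nc(SCc2nc3ccccc3[nH]2)nc1-c1ccccc1`, has not yet been measured. It keeps the shared core and differs from compound 2 in one group: 1,3-thiazol-2-yl in place of pyridin-2-yl on a nitrogen on an aromatic ring. In words, 1,3-thiazol-2-yl sits in place of pyridin-2-yl on a nitrogen on an aromatic ring.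

Among the measured compounds shown here, only one measured step bears on this, and only indirectly: a 4.5-fold higher number from compound 1 to compound 2 (0.65 log units; beyond the scatter), where (pyridin-2-yl)amino replaced chloro. That step exchanged a single atom for a whole ring-bearing group, whereas the new change exchanges one aromatic ring for another. For the measured compounds named here, no measured step compares two such rings, so the data suggest no direction. The expectation in this assay is therefore a smaller step than that one, probably none beyond the scatter. The estimated step is a 1.1-fold lower number from compound 2 to compound 3 (0.05 log units; within the scatter). For compound 3 the expected value is 18 nM, with an estimated range of 5 nM to 65 nM.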

Compound 3, half-maximal inhibitory concentration: 11.9 nM
Compound 3: the middle estimate sits 1.5-fold (0.18 log units) above what was measured; the range from low to high includes it.
By their numbers in this assay, from the lowest: compound 1; then compounds 3 and 2 (each within the scatter of the next).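

In this assay the place on the nitrogen on an aromatic ring tolerates a change of ring: one six-membered aromatic ring with 1 hetero atom gives way to one five-membered aromatic ring with 2 hetero atoms, and the result (a 1.7-fold lower number from compound 2 to compound 3 (0.23 log units; within the scatter)) does not separate pyridin-2-yl from 1,3-thiazol-2-yl. The comparison with chloro now rests on two different rings, since (1,3-thiazol-2-yl)amino (a 2.7-fold higher number from compound 1 to compound 3 (0.43 log units; beyond the scatter)) and (pyridin-2-yl)amino (a 4.5-fold higher number from compound 1 to compound 2 (0.65 log units; beyond the scatter)) both give a higher number than chloro, with each step beyond the scatter and modest in size. No measurement shown here explains either the tolerance of the ring change or the gap from chloro.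

The compounds shown leave open whether a plain phenyl ring on the same nitrogen, with no hetero atom in the ring, would stay level with these two rings. They also leave open whether a saturated amine such as morpholine in place of chloro would fall nearer to compound 1 or to compound 2 and compound 3.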